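Methyl in place of hydrogen on compound 3

This account rests on a few compounds, and the source may have more. Where it says the series, first, only, none or still open, it means among the compounds named here.

Compound 1 `Clc1ccc(C[C@H]2COC[C@@H]2Cc2ccccc2)cc1Cl` gives 19000 nM
Compound 2 `Fc1ccccc1C[C@H]1COC[C@@H]1Cc1ccc(Cl)c(Cl)c1` gives 51000 nM
Compound 3 `Oc1cccc(C[C@H]2COC[C@@H]2Cc2ccc(Cl)c(Cl)c2)c1` gives 31000 nM

In a functional assay on HL-60 cells (Homo sapiens) for cytotoxicity, read by WST assay, with a stated time of 48 h (on this read-out lower numbers stand for an effect already at smaller amounts and higher numbers for an effect only at larger amounts of compound), compound 3 at 31000 nM lies within the scatter of both other compounds, whose own gap is a 2.7-fold higher number from compound 1 to compound 2 (0.43 log units; beyond the scatter) and is the only one beyond it. Compound 4 `COc1cccc(C[C@H]2COC[C@@H]2Cc2ccc(Cl)c(Cl)c2)c1` differs from compound 3 by methyl in place of hydrogen on an oxygen on an aromatic ring as methyl in place of hydrogen on an oxygen on an aromatic ring, hydroxy to methoxy. For the measured compounds named here, no measured step covers this change. The closest evidence is a 1.6-fold higher number from compound 1 to compound 3 (0.21 log units; within the scatter) for the hydroxy itself, alongside a 1.6-fold lower number from compound 2 to compound 3 (0.22 log units; within the scatter) for 3-hydroxyphenyl in place of 2-fluorophenyl. In this assay no step beyond the scatter is therefore expected, and the estimated step is a 1.1-fold lower number from compound 3 to compound 4 (0.04 log units; within the scatter) at most. Compound 4 is estimated at 28000 nM with an expected range from 13000 nM to 60000 nM in this assay.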

Compound 4, half-maximal effective concentration: 73000 nM
Compound 4: middle estimate off by 2.6-fold (0.42 log units), on the low side, outside the stated range (above it).
By their numbers in this assay, from the lowest: compounds 1, 3, 2 and 4 (each within the scatter of the next, the first and the last beyond it).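

In this assay, methyl in place of hydrogen on the oxygen gives a 2.4-fold higher number from compound 3 to compound 4 (0.37 log units; beyond the scatter), so this small change on an oxygen on an aromatic ring moves the number beyond the scatter. Hydroxy in place of hydrogen had stayed within the scatter, whereas methoxy in place of hydrogen gives a 3.8-fold higher number from compound 1 to compound 4 (0.58 log units; beyond the scatter), so among these compounds the methyl on the oxygen makes the difference. Nothing available here accounts for this step.

Going by these compounds, whether an ethyl on that oxygen would carry the number further remains open. So does how an amine in place of the hydroxy would read out.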